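Aminobenzothiazole for quinazoline: rat microsome stability note

The source may report more compounds than this note shows. Statements on the series, on what has been measured and on what is new or still open speak of the compounds shown alone.

Compound 1 `Cc1cc(F)cnc1N1CCN(C(=O)CCCc2cccc3cncnc23)[C@@H](C)C1` has no number in an ADME assay on microsomes from liver (Rattus norvegicus) for metabolic stability, read by LC-MS, with a stated time of 15 min, tested at 1 uM; on this read-out higher numbers stand for a more stable compound and lower numbers for a less stable compound; for compound 1 the result is "not determined" (no result reported), so compound 1 stands nowhere on this read-out. The same holds for compound 2 `N#Cc1cc(N2CCN(C(=O)CCS(=O)(=O)c3cccc4ncsc34)CC2)ccn1`, which in this assay gives "not determined" (no result reported). Going by the values given here, the single number in the set comes from compound 3 `O=C(CCS(=O)(=O)c1cccc2ncsc12)N1CCN(c2ccncc2F)CC1`, which in this assay gives 29%. Compound 3 shares its core with compound 2 rather than with compound 1, so it serves only as a rough anchor for the level at which members of this set sit.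

Compound 4 `Cc1cc(F)cnc1N1CCN(C(=O)CCCc2cccc3nc(N)sc23)[C@@H](C)C1` is the next entry. It differs from compound 1 in one place: 2-amino-1,3-benzothiazol-7-yl in place of quinazolin-8-yl on a saturated chain carbon, three bonds along the chain from a carbonyl carbon. Among the compounds with values here, no measured step exists for this pair and no number for compound 1, so the direction of the change in this assay cannot be read from the data; a step of moderate size in either direction, or none beyond the scatter, all remain open. With compound 3 at 29% as the only anchor in this assay, compound 4 is expected to sit in the middle of the read-out, estimated at 40% with a range from 12% to 78%.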

Compound 4, percent of the compound remaining: 3.7%
For compound 4 the middle estimate is 36.3 percentage points above the measured one; measured number below the stated range.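

No new step can be read: in this assay compound 1 gives "not determined" (no result reported), so the exchange of quinazolin-8-yl for 2-amino-1,3-benzothiazol-7-yl in compound 4 has no size on this read-out. The compounds shown leave open the direction and size of that exchange. Nothing available bears on the result for compound 4.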